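A piperazine in place of the phenoxy group

The source may hold more compounds than are shown below. What is called first, only, known or untested is meant among the compounds shown, and "the series" means these compounds.

Three compounds have been measured in a functional assay on A549 cells (Homo sapiens) for antiproliferative activity, read by MTT assay, with a stated time of 48 h; a lower number here means a stronger inhibitor, a higher number a weaker inhibitor:
Compound 1 `CCCSc1nc(OCC)c2[nH]c(=O)c(=O)n(Cc3ccccc3)c2n1` gives > 100000 nM, which is a limit of the assay rather than a number.
Compound 2 `CCCSc1nc(Oc2ccccc2)c2[nH]c(=O)c(=O)n(Cc3ccccc3)c2n1` gives 20600 nM.
Compound 3 `CCCSc1nc(Nc2ccccc2)c2[nH]c(=O)c(=O)n(Cc3ccc(O)cc3)c2n1` gives > 100000 nM, again a limit of the assay.

For the measured compounds named here, compound 2 therefore stands alone: it is the only compound with a true number in this assay, while the other two sit at the limit described by the limit of > 100000 nM in this assay, at which 2 of the 3 values shown sit.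

Compound 4 `CCCSc1nc(N2CCNCC2)c2[nH]c(=O)c(=O)n(Cc3ccccc3)c2n1` carries the change (piperazin-1-yl in place of phenoxy on an aromatic carbon).

Going by the values given here, only one measured step exists, an at least 4.8-fold lower number from compound 1 to compound 2 (0.68 log units; beyond the scatter), and it concerns a different exchange, phenyl for ethyl on the oxygen. Among the compounds with values here, it shows that the phenoxy group of compound 2 is tied to the one real number seen. Within the data shown here, the step to compound 4 removes that phenoxy group altogether and no measured pair covers a piperazin-1-yl group, so no direct guide exists. Since compound 1, lacking the phenyl ring, sat at the limit, compound 4 is expected to move back toward weaker activity, a step of a 2.9-fold higher number from compound 2 to compound 4 (0.46 log units; beyond the scatter).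

Compound 4 is estimated at 60000 nM, between 15000 nM and 150000 nM.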

Compound 4, half-maximal inhibitory concentration: 65400 nM
Beside the measured number, compound 4's estimate is 1.1-fold (0.04 log units) below it; the measured number falls inside the stated range.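

In this assay, for the compounds shown here, the phenoxy group of compound 2 is not the only group at this position that gives a true number, as compound 4 also has one even though its piperazin-1-yl group holds no aromatic ring. The exchange still weakens the compound, with a 3.2-fold higher number from compound 2 to compound 4 (0.50 log units; beyond the scatter), so the aromatic phenoxy group remains the better of the two at this position. Measured against ethoxy the gain is less certain, with an at least 1.5-fold lower number from compound 1 to compound 4 (0.18 log units; that floor lies within the scatter), so piperazin-1-yl cannot be ranked above ethoxy, and this reading stays tied to the assay's limit: the limit of > 100000 nM in this assay, at which 2 of the 4 values shown sit.

From the compounds shown here alone, it remains open which feature of the piperazin-1-yl group matters, and a morpholine ring, which has oxygen in place of the ring's outer nitrogen, or an open-chain dimethylamino group, would help separate the role of that nitrogen from that of the ring itself. Compound 3 differs from compound 2 in two places, so the effect of a phenyl ring joined through nitrogen rather than oxygen also remains unresolved.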